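This account rests on a few compounds, and the source may have more. Where it says the series, first, only, none or still open, it means among the compounds named here.

Of the compounds shown here, three have so far been tested in an assay for inhibition of kynurenine 3-monooxygenase (Rattus norvegicus), tested at 10 uM; on this read-out lower numbers stand for less inhibition and higher numbers for more inhibition at the one concentration tested (going by the name of the read-out). Compound 1 `COC(=O)C(=O)/C=C(\O)c1ccc(Cl)cc1` gives 38%, and compound 2 `COC(=O)C(=O)/C=C(\O)c1ccc(F)cc1` gives 22%. Among the compounds with values here, the only change between these two is fluoro in place of chloro on an aromatic carbon, and the step of a number 16 percentage points lower from compound 1 to compound 2 (beyond the scatter). Compound 3 `COC(=O)C(=N)/C=C(\O)c1ccc(Cl)c(Cl)c1` is built on a different core; the difference between the two cores is not broken down here. In this assay compound 3 gives 37%, which lies within the scatter of the number for compound 1, so nothing can be said about their order.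

Compound 4 `COC(=O)C(=N)/C=C(\O)c1ccc(F)c(Cl)c1` has not yet been measured. It differs from compound 3 by fluoro in place of chloro on an aromatic carbon. Within the data shown here, this is the same kind of change as the one from compound 1 to compound 2, though here the place is ortho to a chloro group as well as para to a group of 9 heavy atoms, whereas in the earlier pair it was only para to that group. Because the step of a number 16 percentage points lower from compound 1 to compound 2 (beyond the scatter) was a modest lowering, a step of similar size is expected, a number 16 percentage points lower from compound 3 to compound 4 (beyond the scatter) in this assay. Compound 4 is therefore estimated to give 21%, with a likely range from 8% to 36%.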

Compound 4, a percentage reported as inhibition, at one concentration (the size of the read-out at that concentration, not a potency): 4%
Compound 4: middle estimate off by 17 percentage points, on the high side; the whole stated range lies above it.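

In this assay, fluoro in place of chloro on an aromatic carbon again goes with a lower number, here a number 33 percentage points lower from compound 3 to compound 4 (beyond the scatter). The direction of the change carries over from one core to the other, but its size does not: the same change on two cores in this assay, a number 16 percentage points lower (beyond the scatter) from compound 1 to compound 2 and a number 33 percentage points lower (beyond the scatter) from compound 3 to compound 4, 17 percentage points apart, beyond the scatter of two such steps Two pairs are too few to make a rule, and they do not show why the steps differ, since the second pair differs from the first both in its core and in having the changed place ortho to a chloro group, and these compounds cannot separate those two differences.

The aromatic ring in the compounds shown carries only chloro and fluoro groups, which leaves open how a methyl, methoxy or nitrile group in the same place would read on either core. Also open, going by these compounds, is what a carboxylic acid in place of the methyl ester would do to the number in this assay.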